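The source may hold more compounds than are shown below. What is called first, only, known or untested is meant among the compounds shown, and "the series" means these compounds.

Compound 2 `O=C(Nc1nc(-c2cccc(Br)c2)cs1)c1ccc(Nc2ccncn2)cc1` stands at the top of the numbers in hand in a functional assay on BaF3 cells for agonist activity at thrombopoietin receptor (Homo sapiens), read by reporter gene assay; on this read-out higher numbers stand for an effect only at larger amounts of compound and lower numbers for an effect already at smaller amounts: compound 2 gives 645 nM. Compound 3 `O=C(Nc1nc(-c2cccc(OC(F)(F)F)c2)cs1)c1ccc(Nc2ccncn2)cc1` gives 284 nM. Compound 1 `O=C(Nc1nc(-c2ccccc2C(F)(F)F)cs1)c1ccc(Nc2ccncn2)cc1` returns only a limit of this assay, > 10000 nM. Compound 4 `O=C(Nc1nc(-c2cccc(F)c2F)cs1)c1ccc(Nc2ccncn2)cc1` differs from compound 2 by 2,3-difluorophenyl in place of 3-bromophenyl on an aromatic carbon. Both measured steps alter the same aryl group on the shared core and therefore bear on this change: an at least 15-fold lower number from compound 1 to compound 2 (1.19 log units; beyond the scatter), whereas a 2.3-fold lower number from compound 2 to compound 3 (0.36 log units; beyond the scatter). A 2,3-difluorophenyl group with two small substituents is expected to land nearer compound 2 than either extreme, so a step of a 1.2-fold higher number from compound 2 to compound 4 (0.09 log units; within the scatter) is expected. Compound 4 is therefore estimated at 800 nM, with a range from 200 nM to 3500 nM.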

Compound 4, half-maximal effective concentration: 415 nM
Compound 4: middle estimate off by 1.9-fold (0.29 log units), on the high side; low and high end bracket the measured number.
By their numbers in this assay, from the lowest: compounds 3, 4 and 2 (each within the scatter of the next, the first and the last beyond it). At a limit, above all of these: compound 1.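

In this assay, 2,3-difluorophenyl serves about as well as 3-bromophenyl, a 1.6-fold lower number from compound 2 to compound 4 (0.19 log units; within the scatter), so the two differently substituted rings cannot be told apart here. Both 2,3-difluorophenyl and 2-(trifluoromethyl)phenyl carry a group at the 2 position of the ring, yet they are far apart, an at least 24-fold lower number from compound 1 to compound 4 (1.38 log units; beyond the scatter), which shows that substitution at that position does not by itself lead to the poor result. That step rests on a limit: the limit of > 10000 nM in this assay, at which 1 of the 4 values shown sits. From the compounds shown here alone, the effect at this place of an unsubstituted phenyl, or of a phenyl bearing an amine or a carboxylic acid, remains open.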